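Swapping the aryl group on the amine-bearing carbon

A few compounds are considered here, and "the series" means these few. Any claim that something is new, unique, unknown or untested is made for them only; others in the source may bear on it.

Measured compounds:
- compound 1, `CCC[C@H](Nc1cncc(-c2ccc(O)c(OC)c2)n1)c1ccccc1`: 160 nM
- compound 2, `CCCC(Nc1cncc(-c2ccc(O)c(OC)c2)n1)c1ccc(Cl)cc1`: 20000 nM
- compound 3, `CCCC(Nc1cncc(-c2ccc(O)c(OC)c2)n1)c1cccc(OC)c1`: 10000 nM

These three compounds share one core and differ only in the aromatic group attached to the saturated chain carbon that carries the amine. In a functional assay on PC-3 cells (Homo sapiens) for cytotoxicity, read by MTT assay, with a stated time of 72 h (on this read-out higher numbers stand for weaker inhibition and lower numbers for stronger inhibition), compound 2 gives 20000 nM, the highest number among the three. Its nearest neighbour is compound 3, and the step of a 2.0-fold lower number from compound 2 to compound 3 (0.30 log units; within the scatter) is too small to read as a real difference. Compound 1, in contrast, gives 160 nM in this assay, far below both of the others, though it also differs from compound 2 in having a single defined configuration at that carbon.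

Compound 4, `CCCC(Nc1cncc(-c2ccc(O)c(OC)c2)n1)c1cccnc1`, has not yet been measured. Its change from compound 2 is pyridin-3-yl in place of 4-chlorophenyl on a saturated chain carbon bound to a nitrogen on an aromatic ring and a saturated chain carbon. Going by the values given here, the only measured step that bears on this kind of exchange, the one to compound 3, stayed within the scatter. On that basis compound 4 is expected to stay close to compound 2, with a step of about a 1.3-fold lower number from compound 2 to compound 4 (0.12 log units; within the scatter) in this assay and no clear direction. The estimate for compound 4 is therefore 15000 nM, within a range from 4000 nM to 50000 nM.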

Compound 4, half-maximal inhibitory concentration: 300 nM
For compound 4 the middle estimate is 50-fold (1.70 log units) above the measured one; the whole stated range lies above it.
By their numbers in this assay, from the lowest: compounds 1 and 4 (each within the scatter of the next); then compounds 3 and 2 (each within the scatter of the next).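

The aryl group at this position clearly matters in this assay, since pyridin-3-yl gives a 67-fold lower number from compound 2 to compound 4 (1.82 log units; beyond the scatter) and also a 33-fold lower number from compound 3 to compound 4 (1.52 log units; beyond the scatter). Going by these compounds alone, the only earlier exchange at this carbon, a 2.0-fold lower number from compound 2 to compound 3 (0.30 log units; within the scatter), swapped one substituted phenyl group for another and gave no sign that such a large step was possible here. Nothing measured in these compounds explains the large steps to compound 4.

Going by these compounds, it remains open whether the place of the nitrogen in the ring matters, which pyridin-2-yl and pyridin-4-yl groups would test, or whether a second ring nitrogen, as in a pyrimidin-5-yl group, would keep the low number. Also unresolved is how the two single configurations at this carbon would compare with compound 4, which has none defined.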